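The compounds below may be only part of what the source reports. "The series", "measured", "known", "first", "only" and "open" are said of these compounds alone.

Measured compounds:
compound 1, `N#Cc1cncc(N2CC[C@@H]3CN[C@@H]3C2)c1` — 1900 nM
compound 2, `CCOc1cncc(N2CC[C@H]3CN[C@H]3C2)c1` — 620 nM

Among the compounds with values here, in a functional assay on HEK293 cells for agonist activity at Neuronal acetylcholine receptor; alpha4/beta2 (Homo sapiens), read by FLIPR (a lower number here means that less compound is needed, a higher number that more compound is needed for the effect), compound 2 stands at the lower of the two numbers measured so far, and it gives 620 nM. Its nearest neighbour is compound 1, which gives 1900 nM in this assay, a gap that lies beyond the usual scatter. Compound 3, `CCOc1cncc(N2CC[C@@H]3CN[C@@H]3C2)c1`, has not yet been measured in this assay. Compared with compound 2, compound 3 differs only as follows: the two compounds have the same atoms and bonds and differ only in configuration as drawn: 2 of 2 stereo elements differ (all stereocentres are inverted: mirror images); a stereocentre at a saturated ring carbon is drawn S in compound 2 and R in compound 3; a stereocentre at a saturated ring carbon is drawn R in compound 2 and S in compound 3. No measured pair in this set shows what a change of configuration does, so the direction of the step cannot be read from the data shown. Mirror images can differ sharply in this assay, in either direction. Compound 3 is therefore expected to lie at 1800 nM, in a wide range from 400 nM to 9000 nM, a step from compound 2 estimated as a 2.9-fold higher number from compound 2 to compound 3 (0.46 log units; beyond the scatter).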

Compound 3, half-maximal effective concentration: 1350 nM
The estimate for compound 3 lay 1.3-fold (0.12 log units) above the measured number; low and high end bracket the measured number.
By their numbers in this assay, from the lowest: compound 2; then compounds 3 and 1 (each within the scatter of the next).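

In this assay, inverting both stereocentres gives a 2.2-fold higher number from compound 2 to compound 3 (0.34 log units; beyond the scatter), the first measured sign that configuration alone moves the number on this core, though only modestly. The step can be assigned to configuration because nothing else separates the pair: the fact that compounds 2 and 3 differ only in the configuration as drawn. With the configuration held as in compound 3, ethoxy in place of cyano on an aromatic carbon gives a 1.4-fold lower number from compound 1 to compound 3 (0.15 log units; within the scatter), so at this position and in this configuration the assay does not separate the two groups.

The compounds shown leave open whether the same mirror-image step would appear with cyano, or with another group on that aromatic carbon, such as an amine or a longer alkoxy chain. They also leave open how a compound with only one of the two stereocentres inverted would compare.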